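A few compounds are considered here, and "the series" means these few. Any claim that something is new, unique, unknown or untested is made for them only; others in the source may bear on it.

Working notes on the series.

Compound 1 `COc1ccc(Cc2nc(N)n(CC(=O)Nc3ccccc3)c2-c2ccccc2Br)cc1` is the reference point: in a functional assay on A-375 cells (Homo sapiens) for antiproliferative activity, read by MTT assay, with a stated time of 48 h (a higher number here means a weaker inhibitor, a lower number a stronger inhibitor), compound 1 gives 1400 nM. Compound 2 `CC(C)(C)c1ccc(Cc2nc(N)n(CC(=O)Nc3ccccc3)c2-c2ccccc2Br)cc1` differs from it by tert-butyl in place of methoxy on an aromatic carbon, and in this assay compound 2 gives 2800 nM, so the step is a 2.0-fold higher number from compound 1 to compound 2 (0.30 log units; within the scatter). Compound 3 `COc1ccc(Cc2nc(N)n(CC(=O)Nc3ccc(C)cc3)c2-c2ccccc2Br)cc1` differs from compound 1 by methyl in place of hydrogen on an aromatic carbon, and in this assay compound 3 gives 2400 nM, a step of a 1.7-fold higher number from compound 1 to compound 3 (0.23 log units; within the scatter). For the measured compounds named here, since both steps fall within the scatter, the three numbers measured so far are not separated from one another.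

Compound 4 `Cc1ccc(NC(=O)Cn2c(N)nc(Cc3ccc(C(C)(C)C)cc3)c2-c2ccccc2Br)cc1` has not been measured. It differs from compound 3 by tert-butyl in place of methoxy on an aromatic carbon. Going by the values given here, this is the same change as the one from compound 1 to compound 2, and it is made on a core that differs from the core of compound 1 by methyl in place of hydrogen on an aromatic carbon. Among the compounds with values here, the only guide is the earlier pair, where the step was a 2.0-fold higher number from compound 1 to compound 2 (0.30 log units; within the scatter); there is no second example on this core, so the transfer is untested. The expectation in this assay is a step of about a 1.9-fold higher number from compound 3 to compound 4 (0.27 log units; within the scatter) from compound 3 to compound 4, because the earlier step of a 2.0-fold higher number from compound 1 to compound 2 (0.30 log units; within the scatter) was small. Compound 4 is therefore estimated at 4500 nM, with a plausible range from 2000 nM to 10000 nM, and a result within the scatter of compound 3 would not be surprising.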

Compound 4, half-maximal inhibitory concentration: 1400 nM
The estimate for compound 4 lay 3.2-fold (0.51 log units) above the measured number; the measured number lies below the stated range.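

In this assay, tert-butyl in place of methoxy gives a 1.7-fold lower number from compound 3 to compound 4 (0.23 log units; within the scatter), while methyl in place of hydrogen gives a 2.0-fold lower number from compound 2 to compound 4 (0.30 log units; within the scatter), and each of these steps taken alone lies within the scatter. The tert-butyl change therefore does not carry from one core to the other as a step of the same size and direction: the same change on two cores in this assay, a 2.0-fold higher number (0.30 log units; within the scatter) from compound 1 to compound 2 and a 1.7-fold lower number (0.23 log units; within the scatter) from compound 3 to compound 4, 3.4-fold (0.54 log units) apart, beyond the scatter of two such steps The methyl change gives the same picture from the same four compounds, so this is one departure from simple addition of the two changes rather than two separate findings, and it does not show which of the two groups is responsible or whether it extends beyond these compounds: the same change on two cores in this assay, a 1.7-fold higher number (0.23 log units; within the scatter) from compound 1 to compound 3 and a 2.0-fold lower number (0.30 log units; within the scatter) from compound 2 to compound 4, 3.4-fold (0.54 log units) apart, beyond the scatter of two such steps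

The compounds shown leave open whether the same departure appears with a trifluoromethyl group or a longer alkyl chain in place of tert-butyl, or with chlorine or a carboxylic acid in place of the methyl group. Also open, on these data alone, is how both changes behave on a core carrying chlorine in place of bromine.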